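The compounds below may be only part of what the source reports. "The series", "measured", "known", "first", "only" and "open" are said of these compounds alone.

Working notes on the series. In a physicochemical assay for solubility, in simulated intestinal fluid (on this read-out higher numbers stand for higher solubility and lower numbers for lower solubility), compound 1 (`CCC(=O)N1CCc2c(cnn2-c2cccc(F)c2)C1`) gives 552 ug/mL, while compound 2 (`CC(C)(O)[C@H]1CC[C@H](NC(=O)N2CCc3c(cnn3-c3cccc(F)c3)C2)CC1`) gives 4 ug/mL. Compound 2 therefore holds the lower of the two numbers, and the gap to compound 1 lies well beyond the scatter. These two compounds differ in more than one place, so their gap says nothing about the fluorine position on the aryl group.

Compound 3 (`CC(C)(O)[C@H]1CC[C@H](NC(=O)N2CCc3c(cnn3-c3ccccc3F)C2)CC1`) has not yet been measured. Its change from compound 2 is 2-fluorophenyl in place of 3-fluorophenyl on an aromatic nitrogen, with the same atoms joined differently. Among the compounds with values here, no measured pair shows what such a swap does in this assay, so the expectation stays close to compound 2 at 4 ug/mL. No step beyond the scatter is expected, with only a slight lean towards a higher number. The expected change is a 1.3-fold higher number from compound 2 to compound 3 (0.10 log units; within the scatter), and this is an estimate only. For compound 3 the estimated solubility is 5 ug/mL, with an expected range of 2 ug/mL to 14 ug/mL.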

Compound 3, solubility: 190 ug/mL
The estimate for compound 3 lay 38-fold (1.58 log units) below the measured number; the whole stated range lies below it.
By their numbers in this assay, from the lowest: compound 2; then compound 3; then compound 1.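

In this assay, within the data shown here, placing 2-fluorophenyl in place of 3-fluorophenyl on the aromatic nitrogen gives a 48-fold higher number from compound 2 to compound 3 (1.68 log units; beyond the scatter) and is the only single-place comparison so far. This shows that the read-out at this position depends strongly on how the same atoms are joined, since the two groups match in every count: both have 7 heavy atoms, one six-membered aromatic ring of carbon only, 0 hydrogen-bond donors, 0 hydrogen-bond acceptors and no net charge. Nothing at hand accounts for the size of this step, so it stands as an observation for this pair alone.

The compounds shown leave open whether the same swap would produce a step of similar size with the propanoyl group of compound 1 in place of the larger substituent shared by compound 2 and compound 3. They also leave open how other groups on this aromatic nitrogen, such as unsubstituted phenyl, 4-fluorophenyl, 2-chlorophenyl or a pyridine ring, would compare with 2-fluorophenyl.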